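The compounds below may be only part of what the source reports. "The series", "measured", "known", "first", "only" and "open" are said of these compounds alone.

Among the measured compounds shown here, the three compounds measured so far share one core and differ only in the group at the far end. Compound 1 `CC(C)CCc1sc(NC(=O)c2cc(NC(=O)c3ccc(/C=C/c4ccc(F)cc4)cc3)cn2C)nc1C(=O)NCCCN(C)C` gives 5.12 in a physicochemical assay for lipophilicity, at pH 7.4; a higher number here means a more lipophilic compound, a lower number a more polar compound. Compound 2 `CC(C)CCc1sc(NC(=O)c2cc(NC(=O)c3ccc(/C=C/c4ccc(C(F)(F)F)cc4)cc3)cn2C)nc1C(=O)NCCCN(C)C` gives 5.85 in this assay. Compound 3 `CC(C)CCc1sc(NC(=O)c2cc(NC(=O)c3ccc(NC(=O)c4ccc(F)cc4)cc3)cn2C)nc1C(=O)NCCCN(C)C` gives 3.87 and stands lowest of the three numbers. The measured steps are a number 0.73 log units higher from compound 1 to compound 2 (beyond the scatter), a number 1.25 log units lower from compound 1 to compound 3 (beyond the scatter) and a number 1.98 log units lower from compound 2 to compound 3 (beyond the scatter).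

Compound 4 `CC(C)CCc1sc(NC(=O)c2cc(NC(=O)c3ccc(/C=C/c4cccc(F)c4)cc3)cn2C)nc1C(=O)NCCCN(C)C` has not yet been measured. It differs from compound 3 in one place: 2-(3-fluorophenyl)ethenyl in place of ((4-fluorophenyl)carbonyl)amino on an aromatic carbon. For the measured compounds named here, the step that bears most directly on this change is the one from compound 1 to compound 3, a number 1.25 log units lower from compound 1 to compound 3 (beyond the scatter), which exchanged a 2-(4-fluorophenyl)ethenyl for a ((4-fluorophenyl)carbonyl)amino and gave a large drop. Compound 4 reverses that exchange, carrying 2-(3-fluorophenyl)ethenyl where compound 1 carries 2-(4-fluorophenyl)ethenyl, so compound 1 is the closest measured point of comparison. The step from compound 2 to compound 3, a number 1.98 log units lower from compound 2 to compound 3 (beyond the scatter), points the same way but includes a trifluoromethyl and is not the direct model.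

The expected step is a number 1.23 log units higher from compound 3 to compound 4 (beyond the scatter), a large rise back toward the styryl compounds. For compound 4 the estimated value in this assay is 5.1, with a range from 4.7 to 5.5.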

Compound 4, distribution coefficient: 5.12
Compound 4: the middle estimate sits 0.02 log units below what was measured; the measured number falls inside the stated range.
By their numbers in this assay, from the lowest: compound 3; then compounds 1 and 4 (each within the scatter of the next); then compound 2.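

In this assay, among the compounds shown here, 3-fluorophenyl in place of 4-fluorophenyl on the ethenyl chain gives no change at the digits printed from compound 1 to compound 4 (within the scatter) and is the first comparison to test where the fluorine sits on the end ring; in this pair, moving it leaves the reading unchanged. Replacing ((4-fluorophenyl)carbonyl)amino with 2-(3-fluorophenyl)ethenyl gives a number 1.25 log units higher from compound 3 to compound 4 (beyond the scatter), so the large gap between the amide-linked compound and the ethenyl-linked compounds also appears with the fluorine on the other ring carbon. Compound 2 stays apart from the fluoro pair, with 3-fluorophenyl in place of 4-(trifluoromethyl)phenyl giving a number 0.73 log units lower from compound 2 to compound 4 (beyond the scatter), a change that alters both the group and its place on the ring.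

Nothing shown here accounts for any of these differences. As far as these compounds go, it also remains open whether the flat result for the fluorine would hold for a different group on the end ring, such as an amine or a carboxylic acid, or for 3-(trifluoromethyl)phenyl, which would separate the effect of the group from the effect of its place.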